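This account rests on a few compounds, and the source may have more. Where it says the series, first, only, none or still open, it means among the compounds named here.

Compound 3 `c1coc(-c2ccccc2OCC2=NCCN2)c1` is the only one of the three measured compounds with a number in a functional assay for activation of Alpha-1B adrenergic receptor (Homo sapiens), read by calcium flux (a higher number here means that more compound is needed for the effect, a lower number that less compound is needed), where compound 3 gives 10 nM. Compound 1 `Cc1ccnc(-c2ccccc2OCC2=NCCN2)c1` reaches only a limit of this assay, < 100000 nM. Compound 2 `Cc1cccc(-c2ccccc2OCC2=NCCN2)n1` likewise reaches only a limit of this assay, < 100000 nM. Among the compounds with values here, two of the three values shown thus sit at the limit of < 100000 nM in this assay, at which 2 of the 3 values shown sit, so no step between measured compounds can be computed. Compound 4 `c1ccc(-c2nccs2)c(OCC2=NCCN2)c1` is not yet measured; it differs from compound 3 by 1,3-thiazol-2-yl in place of furan-2-yl on an aromatic carbon. Within the data shown here, with no measured step to rest on, the expected step of a 3.0-fold higher number from compound 3 to compound 4 (0.48 log units; beyond the scatter) is modest, a slight loss at most, and may lie within the scatter. Compound 4 is estimated at 30 nM in this assay, within 5 nM to 200 nM.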

Compound 4, half-maximal effective concentration: 20 nM
Compound 4: the middle estimate sits 1.5-fold (0.18 log units) above what was measured, and the stated range covers the measured number.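

On the aromatic carbon ortho to a group of 7 heavy atoms, 1,3-thiazol-2-yl in place of furan-2-yl gives a 2.0-fold higher number from compound 3 to compound 4 (0.30 log units; within the scatter) in this assay. This only readable step shows that this position accepts a five-membered aromatic ring with 2 hetero atoms as well as one with 1 hetero atom, with no change beyond the scatter. Steps involving compound 1 or compound 2 cannot be read: the limit of < 100000 nM in this assay, at which 2 of the 4 values shown sit.

From the compounds shown here alone, whether an amine or a carboxylic acid on this aromatic carbon would hold the number in this assay stays open. Changes elsewhere on the shared core also remain untested in the compounds shown.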